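A chloromethyl extension on the acyl chain of compound 2

The source may hold more compounds than are shown below. What is called first, only, known or untested is meant among the compounds shown, and "the series" means these compounds.

Compound 1 `CCC(=O)Nc1ccc(S(=O)(=O)Oc2ccccc2C(C)C)cc1` gives 11000 nM in a functional assay on M21 cells (Homo sapiens) for antiproliferative activity, read by sulforhodamine B assay, with a stated time of 48 h; on this read-out higher numbers stand for weaker inhibition and lower numbers for stronger inhibition.
Compound 2 `CCC(=O)Nc1ccc(S(=O)(=O)Oc2ccccc2I)cc1` gives 11000 nM in this assay.
Compound 3 `CC(C)c1ccccc1OS(=O)(=O)c1ccc(NC(=O)C(C)(C)C)cc1` gives 6200 nM in this assay.

Compound 2 stands level with compound 1, the two together giving the highest numbers of the three; the step of no change at the digits printed from compound 1 to compound 2 (within the scatter) is within the scatter, and the value of compound 3 differs from that of compound 2 only within the scatter as well. Compound 4 `O=C(CCCCl)Nc1ccc(S(=O)(=O)Oc2ccccc2I)cc1` differs from compound 2 by chloromethyl in place of hydrogen on a saturated chain carbon, two bonds along the chain from a carbonyl carbon. Going by the values given here, the only measured step at the acyl group, a 1.8-fold lower number from compound 1 to compound 3 (0.25 log units; within the scatter), stayed within the scatter, so a change on the saturated chain is expected to give no step beyond the scatter in this assay, that is a 1.2-fold lower number from compound 2 to compound 4 (0.06 log units; within the scatter). Compound 4 is therefore estimated at 9500 nM, with a range from 4000 nM to 23000 nM.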

Compound 4, half-maximal inhibitory concentration: 7200 nM
Beside the measured number, compound 4's estimate is 1.3-fold (0.12 log units) above it, within the range that was stated.
By their numbers in this assay, from the lowest: compounds 3, 4, 1 and 2 (each within the scatter of the next).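

Extending the acyl chain of compound 2 with chloromethyl, to give the (3-chloropropyl)carbonyl group, produces no step beyond the scatter in this assay (a 1.5-fold lower number from compound 2 to compound 4 (0.18 log units; within the scatter)). This saturated chain carbon therefore accepts a chlorine-bearing extension without a clear change in the read-out, which the earlier step at the acyl group, a change on the carbonyl carbon, could not show. No evidence at hand bears on this result. As far as these compounds go, whether an amine or a carboxylic acid at this position, or a longer chain, would give a step beyond the scatter remains open.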